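The source may hold more compounds than are shown below. What is called first, only, known or untested is meant among the compounds shown, and "the series" means these compounds.

In a physicochemical assay for lipophilicity, using the shake flask method (a higher number here means a more lipophilic compound, a lower number a more polar compound), compound 1 `CC(C)Oc1cc(Oc2ccc(S(C)(=O)=O)cc2)cc(-c2cccc(=O)[nH]2)c1` gives 2.82. For the measured compounds named here, this is the higher of the two numbers available so far, the other being that of compound 2 `CC(C)Oc1cc(Oc2ccc(S(C)(=O)=O)cc2)cc(-c2nccc(=O)[nH]2)c1`, which gives 2.14. Compound 3 `COc1cnc(-c2cc(Oc3ccc(S(C)(=O)=O)cc3)cc(OC(C)C)c2)[nH]c1=O` has not yet been measured. Its structure differs from that of compound 1 as follows: a group of 9 heavy atoms (5 carbon, 2 nitrogen, 2 oxygen; one six-membered aromatic ring with 2 hetero atoms) in place of a group of 7 heavy atoms (5 carbon, 1 nitrogen, 1 oxygen; one six-membered aromatic ring with 1 hetero atom), on an aromatic carbon. The change lies meta to an isopropoxy group and meta to a large group.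

Going by the values given here, only one measured step bears on this change: a number 0.68 log units lower from compound 1 to compound 2 (beyond the scatter). That step likewise replaces a six-membered aromatic ring with 1 hetero atom by one with 2 hetero atoms. Among the compounds with values here, the group entering in compound 3 is larger, however, and no measured compound shows how that extra part behaves in this assay. A modest move to a lower number is therefore expected, probably somewhat smaller than the measured step, though the data cannot settle this. The expected step is a number 0.47 log units lower from compound 1 to compound 3 (beyond the scatter). For compound 3 the estimated value is 2.35, with an expected range of 1.9 to 2.8.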

Compound 3, distribution coefficient: 2.21
The estimate for compound 3 lay 0.14 log units above the measured number; the measured number falls inside the stated range.
By their numbers in this assay, from the lowest: compounds 2 and 3 (each within the scatter of the next); then compound 1.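

In this assay, replacing the ring of compound 1 with the methoxy-bearing ring with 2 hetero atoms gives a number 0.61 log units lower from compound 1 to compound 3 (beyond the scatter), a modest step of the same kind as a number 0.68 log units lower from compound 1 to compound 2 (beyond the scatter). The methoxy can also be read on its own, since compounds 2 and 3 differ only by methoxy in place of hydrogen on an aromatic carbon: a number 0.07 log units higher from compound 2 to compound 3 (within the scatter), so the two compounds cannot be told apart here, and the distance of both from compound 1 goes with the ring exchange they share rather than with the methoxy. Nothing measured here gives a reason for this result.

The compounds shown rest on this single substituent, so it remains open whether a longer chain such as ethoxy, or an amine or a carboxylic acid, on the same carbon would also stay within the scatter of compound 2. On these data alone, it also remains open whether a methoxy on the ring of compound 1, with its 1 hetero atom, would read as it does on the ring with 2 hetero atoms.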